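The compounds below may be only part of what the source reports. "The series", "measured", "known", "first", "only" and "open" are said of these compounds alone.

Measured compounds:
Compound 1, `CCN(CCCCOc1ccc(/C=C/C(=O)c2ccc(N(C)C)cc2O)cc1)Cc1ccccc1OC`, an assay on isolated protein for inhibition of Amine oxidase [flavin-containing] A (Homo sapiens); a higher number here means a weaker inhibitor, a lower number a stronger inhibitor: 9200 nM
Compound 2, `CCN(CCCCOc1ccc(/C=C/C(=O)c2ccc(N(C)C)cc2O)cc1)Cc1ccccc1N(C)C`, this assay: 12300 nM
Compound 3, `CCN(CCCCCCOc1ccc(C(=O)/C=C/c2ccc(N(C)C)cc2)c(O)c1)Cc1ccccc1OC`, this assay: 54300 nM

Compound 1 and compound 2 share one core and differ in a single place: dimethylamino in place of methoxy on an aromatic carbon. The step from compound 1 to compound 2 in this assay is a 1.3-fold higher number from compound 1 to compound 2 (0.13 log units; within the scatter), so the two compounds cannot be told apart on this read-out.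

Compound 3 is built on a different core; the difference between the two cores is not broken down here. Its value in this assay is the highest of the three, and both measured compounds on the other core sit well below it.

Compound 4, `CCN(CCCCCCOc1ccc(C(=O)/C=C/c2ccc(N(C)C)cc2)c(O)c1)Cc1ccccc1N(C)C`, has not yet been measured. It stands to compound 3 as compound 2 stands to compound 1: dimethylamino in place of methoxy on an aromatic carbon. The place of the change reads the same in both pairs, so this is the same change, now made on the core of compound 3.

Going by the values given here, because the only measured instance of this change gave a 1.3-fold higher number from compound 1 to compound 2 (0.13 log units; within the scatter), compound 4 is expected to stay close to compound 3, with an estimated step of a 1.2-fold higher number from compound 3 to compound 4 (0.08 log units; within the scatter). That expectation rests on a single pair on a different core, so it is held loosely. For compound 4 in this assay the estimate is 65000 nM, with a likely range from 30000 nM to 140000 nM.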

Compound 4, half-maximal inhibitory concentration: 37800 nM
Estimate against measurement, compound 4: 1.7-fold (0.24 log units) above; low and high end bracket the measured number.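

On the core of compound 3, dimethylamino in place of methoxy on an aromatic carbon gives a 1.4-fold lower number from compound 3 to compound 4 (0.16 log units; within the scatter) in this assay, so this pair, like the earlier one, cannot be told apart on this read-out. Set side by side, the two steps do not differ: the same change on two cores in this assay, a 1.3-fold higher number (0.13 log units; within the scatter) from compound 1 to compound 2 and a 1.4-fold lower number (0.16 log units; within the scatter) from compound 3 to compound 4, 1.9-fold (0.28 log units) apart, within the scatter of two such steps. Going by these compounds alone, the change from 2-methoxybenzyl to 2-(dimethylamino)benzyl therefore carries across these two cores with no step that stands clear of the scatter, but this rests on only two pairs, gives the change no direction, and shows neither how it would behave on any further core nor what separates the two cores themselves.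

The compounds shown leave open whether a different group at this same place, such as a hydroxyl, a chlorine atom or a pyrrolidine ring, would move the number beyond the scatter when methoxy and dimethylamino do not. They also leave open what a different amine substituent in place of the ethyl group, or a chain of another length between the amine and the ring oxygen on a single core, would do in this read-out.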